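The compounds below may be only part of what the source reports. "The series", "measured", "known", "first", "only" and "open" are said of these compounds alone.

Going by the values given here, compound 2 `CC(Sc1nc2nn(C3COC3)cc2c(=O)n1-c1ccccc1)c1ccccc1` gives the highest of the three numbers so far in a physicochemical assay for solubility, using the shake flask method, in phosphate buffer, with a stated time of 24 h, at pH 7.4 (a higher number here means a more soluble compound, a lower number a less soluble compound), at 26000 nM. Its nearest neighbour is compound 3 `CC(Sc1nc2nn(C3(C)COC3)cc2c(=O)n1-c1ccccc1)c1ccccc1`, which gives 19000 nM; the furthest is compound 1 `O=c1c2cn(C3COC3)nc2nc(SCc2cccc(F)c2)n1-c1ccccc1`, which gives 5000 nM. Among the compounds with values here, the step from compound 1 to compound 2 is a 5.2-fold higher number from compound 1 to compound 2 (0.72 log units; beyond the scatter), the only step here beyond the scatter, and it concerns the substituent on the sulfur. The step from compound 2 to compound 3 is a 1.4-fold lower number from compound 2 to compound 3 (0.14 log units; within the scatter).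

Compound 4 `CC(Sc1nc2nn(C3COC3)cc2c(=O)n1-c1ccccc1)c1cccnc1` has not been measured in this assay. It differs from compound 2 as follows: pyridin-3-yl in place of phenyl on a saturated chain carbon bound to a saturated chain carbon and a sulfur. Neither measured step touches this position, so nothing measured bears directly on it; the closest in kind is the sulfur-substituent step, which was modest. The estimate for compound 4 is therefore anchored on compound 2 at 26000 nM, with a wide range to cover the unknown. Compound 4 is expected to give 40000 nM, between 15000 nM and 120000 nM, a step of a 1.5-fold higher number from compound 2 to compound 4 (0.19 log units; within the scatter), which is to be read as an expectation only.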

Compound 4, solubility: 189000 nM
Compound 4: middle estimate off by 4.7-fold (0.67 log units), on the low side, outside the stated range (above it).
By their numbers in this assay, from the lowest: compound 1; then compounds 3 and 2 (each within the scatter of the next); then compound 4.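

Going by these compounds alone, the ring on the saturated chain carbon bound to a saturated chain carbon and a sulfur, which no earlier step touched, is a sensitive place in this assay: pyridin-3-yl in place of phenyl gives a 7.3-fold higher number from compound 2 to compound 4 (0.86 log units; beyond the scatter), although the heavy-atom count of the group stays the same and only a hydrogen-bond acceptor enters. Within the data shown here, the 1-(pyridin-3-yl)ethyl group in place of 3-fluorobenzyl on a sulfur gives a 38-fold higher number from compound 1 to compound 4 (1.58 log units; beyond the scatter), the only step that is graded large. No measured evidence accounts for the size of either step.

Still open is whether the ring nitrogen must stand as in pyridin-3-yl, since pyridin-2-yl and pyridin-4-yl do not appear among these compounds. Also open, as far as these compounds go, are a pyrimidine ring or a dimethylamino group on the phenyl at this place, and whether the pyridin-3-yl change carries over to the methyl-bearing saturated ring of compound 3.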